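A few compounds are considered here, and "the series" means these few. Any claim that something is new, unique, unknown or untested is made for them only; others in the source may bear on it.

Compound 3, `O=C(NC[C@@H]1C[C@@H]2C=C[C@@H]1C2)NS(=O)(=O)N1CCC(CCNC(=O)c2cc(Cl)ccn2)CC1`, gives 32% in a functional assay on the whole organism (blood) with Rattus norvegicus as the target, with stated times of 24 h and 1 h, at a dose of 5 mg/kg by the intraperitoneal route; a lower number here means a weaker effect, a higher number a stronger effect of the compound at the dose given. Of the three numbers in hand this is the highest, though its standing is mixed. Compound 1, `COc1ccc(Cl)cc1C(=O)NCCC1CCN(S(=O)(=O)NC(=O)NC[C@@H]2C[C@@H]3CC[C@@H]2O3)CC1`, gives 30% in this assay, a number within the scatter of compound 3, so no order between the two can be read. Compound 2, `O=C(NC1CCCCC1)NS(=O)(=O)N1CCC(CCNC(=O)c2csnn2)CC1`, gives 19%, which lies beyond the scatter below compound 3.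

Compound 4, `O=C(NC[C@@H]1C[C@@H]2C=C[C@@H]1C2)NS(=O)(=O)N1CCC(CCNC(=O)c2cccc3c2OCCO3)CC1`, has not yet been measured. It differs from compound 3 at a single place: 2,3-dihydro-1,4-benzodioxin-5-yl in place of 4-chloropyridin-2-yl on a carbonyl carbon. Among the compounds with values here, no pair of measured compounds isolates such a change, so its effect cannot be read from the data, and the three measured values all fall in a narrow window. A step of a number 4 percentage points lower from compound 3 to compound 4 (within the scatter) is therefore expected, one that would stay within the scatter rather than point clearly up or down. Compound 4 is accordingly estimated at 28%, with a range from 12% to 45%.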

Compound 4, a percentage reported as activity, at one dose (the size of the read-out at that dose, not a potency): 11%
For compound 4 the middle estimate is 17 percentage points above the measured one, and the stated range ends above it.
By their numbers in this assay, from the lowest: compounds 4 and 2 (each within the scatter of the next); then compounds 1 and 3 (each within the scatter of the next).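

At this place, on a carbonyl carbon, the choice of group matters in this assay: 2,3-dihydro-1,4-benzodioxin-5-yl in place of 4-chloropyridin-2-yl gives a number 21 percentage points lower from compound 3 to compound 4 (beyond the scatter). Within the data shown here, this is the first change in one place that can be read here, as the earlier compounds differed in more than one place and offered no such comparison. Nothing in the data says which part of the exchange accounts for the step, whether the ring nitrogen, the chlorine or the added oxygen-bearing ring.

A plain phenyl or an unsubstituted pyridin-2-yl on this carbonyl would begin to separate those parts. Going by these compounds, it also remains open whether the same exchange would give a similar step with the cyclohexyl group of compound 2 on the other side of the molecule.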